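Series notes: pentyl in place of (pyridin-4-yl)methyl

The source may hold more compounds than are shown below. What is called first, only, known or untested is meant among the compounds shown, and "the series" means these compounds.

Three compounds of the series have been run in an ADME assay on Huh-7 cells (Homo sapiens) for cytotoxicity; a lower number here means that less compound is tolerated, a higher number that more compound is tolerated. Compound 1 `Cc1ccccc1-c1nn(-c2ccc(F)cc2F)cc1CNCCCCO` carries 3-hydroxypropyl on a saturated chain carbon bound to an amine nitrogen; in this assay compound 1 gives > 20000 nM, a limit of the assay rather than a number. Compound 2 `Cc1ccccc1-c1nn(-c2ccc(F)cc2F)cc1CNCc1ccncc1` carries pyridin-4-yl at the same place; in this assay compound 2 gives > 20000 nM, again a limit. Compound 3 `CN1CCN(CCNCc2cn(-c3ccc(F)cc3F)nc2-c2ccc(S(=O)(=O)N(C)C)cc2)CC1` is the third measured compound; in this assay compound 3 gives > 20000 nM, also a limit. The step that the two limits leave unreadable from compound 1 to compound 2 is therefore unreadable, as both of its ends sit at the limit of > 20000 nM in this assay, at which 3 of the 3 values shown sit. Compound 2 thus stands only at a limit; no number places it among the values shown.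

Compound 4 `CCCCCNCc1cn(-c2ccc(F)cc2F)nc1-c1ccccc1C` differs from compound 2 in one place: butyl in place of pyridin-4-yl on a saturated chain carbon bound to an amine nitrogen. For the measured compounds named here, no measured step bears directly on this change; the one recorded step, from 3-hydroxypropyl to pyridin-4-yl, cannot be sized, and all three measured values rest at the same limit. With nothing pointing beyond the scatter in either direction, the step of a number no higher from compound 2 to compound 4 (the limit leaves the size open) is expected to be small or none, with a limit again the likeliest outcome. Compound 4 is accordingly estimated at 20000 nM, with a range from 8000 nM to 60000 nM.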

Compound 4, half-maximal cytotoxic concentration: 17000 nM
Compound 4: the middle estimate sits 1.2-fold (0.07 log units) above what was measured; the measured number falls inside the stated range.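

In this assay, for the compounds shown here, compound 4 gives 17000 nM as the first number of the series rather than a limit, so a place on a saturated chain carbon bound to an amine nitrogen now has one readable end. The change reads as an at least 1.1-fold lower number from compound 2 to compound 4 (0.07 log units; that floor lies within the scatter) when butyl replaces pyridin-4-yl, and as an at least 1.1-fold lower number from compound 1 to compound 4 (0.07 log units; that floor lies within the scatter) when methyl replaces hydroxy on a saturated chain carbon, four bonds along the chain from an amine nitrogen. Both are floors and not sizes, so neither exchange is shown to go beyond the scatter, and neither is shown to stay within it, as the other compounds still rest at a limit: the limit of > 20000 nM in this assay, at which 3 of the 4 values shown sit.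

On these data alone, how far compound 1 and compound 2 truly sit from compound 4 stays open, and so does whether a longer chain, a carboxylic acid or a tertiary amine at this place would bring a number clearly beyond the scatter. Compound 3 differs from the others in more than one place and offers no comparison with them.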